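The source may hold more compounds than are shown below. What is called first, only, known or untested is meant among the compounds shown, and "the series" means these compounds.

Measured so far in a functional assay on isolated protein for agonist activity at Glucose-dependent insulinotropic receptor (Homo sapiens), read by HTRF and cAMP accumulation; on this read-out lower numbers stand for smaller maximal responses and higher numbers for larger maximal responses:
compound 1 `CC(C)(C)OC(=O)N1CCC(O[C@H]2CC[C@H](Oc3ccc(S(C)(=O)=O)c(F)c3)CC2)CC1` gives 106%;
compound 2 `Cc1nc(O[C@H]2CC[C@H](OC3CCN(C(=O)OC(C)(C)C)CC3)CC2)ccc1C(=O)N(C)C` gives 121%;
compound 3 `CC1(OC(=O)N2CCC(O[C@H]3CC[C@H](Oc4cnc(S(C)(=O)=O)cn4)CC3)CC2)CC1` gives 118%.

Compound 3 stands second highest of the three numbers. Its nearest neighbour is compound 2, whose value lies within the scatter of that of compound 3, so no order between these two can be read. Compound 1 stands furthest off, its value beyond the scatter and lower than that of compound 3. Among the measured compounds shown here, all three numbers sit at or above the reference response, so the series so far reaches a full maximal response whatever the groups at either end of the shared core.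

Compound 4 `CS(=O)(=O)c1cnc(O[C@H]2CC[C@H](OC3CCN(CC4(C(F)(F)F)CCC4)CC3)CC2)cn1` has not yet been measured in this assay. It differs from compound 3 in one place: (1-(trifluoromethyl)cyclobutyl)methyl in place of ((1-methylcyclopropyl)oxy)carbonyl on an amine nitrogen in a ring. For the measured compounds named here, no pair of measured compounds differs in only this place, so nothing measured tells how this exchange acts on the largest response. Across the three measured compounds the largest response changes little even where groups differ at both ends, and this is the only ground for expecting a step from compound 3 to compound 4 in this assay that stays within the scatter, or none at all. Compound 4 is therefore expected to give about 112%, with a likely range from 95% to 130%. The estimated step this means is a number 6 percentage points lower from compound 3 to compound 4 (within the scatter).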

Compound 4, largest response reached (Emax), in percent of the reference or control that the assay uses: 96%
Compound 4: middle estimate off by 16 percentage points, on the high side; measured number inside the range.
By their numbers in this assay, from the lowest: compounds 4 and 1 (each within the scatter of the next); then compounds 3 and 2 (each within the scatter of the next).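

In this assay, (1-(trifluoromethyl)cyclobutyl)methyl in place of ((1-methylcyclopropyl)oxy)carbonyl on the amine nitrogen in a ring gives a number 22 percentage points lower from compound 3 to compound 4 (beyond the scatter), the only step among the compounds shown that isolates a single place, so the group on this nitrogen can alter the largest response. A substantial response nevertheless survives the loss of the carbonyl and of both hydrogen-bond acceptors of the leaving group, with compound 4 at 96% in this assay, but the three-membered ring, the carbonyl, the oxygens and the fluorines all change together, and the step cannot assign the drop to any one of them. No measurement at hand accounts for the step.

Still open, as far as these compounds go, is whether the carbonyl or the trifluoromethyl matters more: a plain cyclobutylmethyl group, or a carbonyl bearing the 1-(trifluoromethyl)cyclobutyl group, would help separate the two. Also open, from the compounds shown here alone, is whether the same exchange lowers the response when the other end of the molecule carries the groups of compound 1 or compound 2.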